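The compounds below may be only part of what the source reports. "The series", "measured", "known", "first", "only" and "open" are said of these compounds alone.

Compound 1 `CC(=O)N(C)c1ccc2[nH]c(-c3n[nH]c4ccccc34)cc2n1`: in a functional assay on SMMC-7721 cells (Homo sapiens) for antiproliferative activity, read by MTT assay, with a stated time of 72 h (a higher number here means a weaker inhibitor, a lower number a stronger inhibitor), compound 1 gives 23400 nM.
Compound 2 `CCC(=O)N(C)c1ccc2[nH]c(-c3n[nH]c4ccccc34)cc2n1`: in this assay compound 2 gives 33500 nM.
Compound 3 `CN(C(=O)c1ccc(F)cc1)c1ccc2[nH]c(-c3n[nH]c4ccccc34)cc2n1`: in this assay compound 3 gives 9150 nM.

Compound 3 stands at the lowest of the three numbers. Its nearest neighbour is compound 1, with a 2.6-fold lower number from compound 1 to compound 3 (0.41 log units; beyond the scatter); further away is compound 2, with a 3.7-fold lower number from compound 2 to compound 3 (0.56 log units; beyond the scatter). Between the two smaller amides the step is a 1.4-fold higher number from compound 1 to compound 2 (0.16 log units; within the scatter).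

Compound 4 `CN(C(=O)c1ccc(Br)cc1)c1ccc2[nH]c(-c3n[nH]c4ccccc34)cc2n1` differs from compound 3 by bromo in place of fluoro on an aromatic carbon. For the measured compounds named here, none of the measured steps exchanges one halogen for another; the two that bear on compound 3, a 2.6-fold lower number from compound 1 to compound 3 (0.41 log units; beyond the scatter) and a 3.7-fold lower number from compound 2 to compound 3 (0.56 log units; beyond the scatter), both replace an alkyl group on the carbonyl carbon by the 4-fluorophenyl group and are modest in size. What part of that gain belongs to the fluoro itself cannot be read from the three compounds. The swap to bromo is therefore expected to leave this assay close to where compound 3 sits, with no step beyond the scatter expected in either direction. Compound 4 is expected to give 8000 nM, within a range of 3000 nM to 20000 nM. This expectation amounts to a 1.1-fold lower number from compound 3 to compound 4 (0.06 log units; within the scatter).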

Compound 4, half-maximal inhibitory concentration: 3460 nM
Compound 4: the middle estimate sits 2.3-fold (0.36 log units) above what was measured; the measured number falls inside the stated range.
By their numbers in this assay, from the lowest: compound 4; then compound 3; then compounds 1 and 2 (each within the scatter of the next).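

The halogen itself matters at this position: in this assay bromo in place of fluoro on the aromatic carbon gives a 2.6-fold lower number from compound 3 to compound 4 (0.42 log units; beyond the scatter), so the step is beyond the scatter. The earlier compounds shown here could only show the 4-fluorophenyl group replacing an alkyl group as a whole, whereas the 4-bromophenyl group on the carbonyl carbon gives larger steps, a 6.8-fold lower number from compound 1 to compound 4 (0.83 log units; beyond the scatter) and a 9.7-fold lower number from compound 2 to compound 4 (0.99 log units; beyond the scatter), than the 4-fluorophenyl group did. Among these four compounds, the choice of halogen therefore moves the number as well as the exchange of alkyl for aryl.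

The compounds shown leave open how chloro, iodo or trifluoromethyl on the same carbon would read, and how much of the step an unsubstituted phenyl on the carbonyl carbon would already carry. Nothing measured here bears on why the two halogens differ.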